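Working notes: from 3-methylphenyl to 2,3-dihydro-1H-indol-4-yl

A few compounds are considered here, and "the series" means these few. Any claim that something is new, unique, unknown or untested is made for them only; others in the source may bear on it.

Values in a physicochemical assay for lipophilicity, at pH 7.4; on this read-out lower numbers stand for lower lipophilicity and higher numbers for higher lipophilicity:
- compound 1 `CNC(=O)c1cc(C(=O)NC2CC2)cn(Cc2ccc(C)cc2)c1=O`: 3.5
- compound 2 `CNC(=O)c1cc(C(=O)NC2CC2)cn(Cc2cccc(C)c2)c1=O`: 3.6

For the measured compounds named here, the two measured compounds cannot be told apart in this assay: the only measured step is a number 0.10 log units higher from compound 1 to compound 2 (within the scatter). Next in the series is compound 3 `CNC(=O)c1cc(C(=O)NC2CC2)cn(Cc2cccc3c2CCN3)c1=O`, which has 2,3-dihydro-1H-indol-4-yl in place of 3-methylphenyl on a saturated chain carbon bound to an aromatic nitrogen. Going by the values given here, the measured step exchanges only 4-methylphenyl for 3-methylphenyl, so it offers no precedent for this kind of change and sets only the starting point. Going by the counts in the structural change, and starting from compound 2 at 3.6, a modest move towards lower numbers is expected, with wide uncertainty. The expected change is a number 0.40 log units lower from compound 2 to compound 3 (beyond the scatter). Compound 3 is estimated at 3.2, within an expected range of 2.7 to 3.7.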

Compound 3, distribution coefficient: 2.1
The estimate for compound 3 lay 1.10 log units above the measured number, and the stated range ends above it.
By their numbers in this assay, from the lowest: compound 3; then compounds 1 and 2 (each within the scatter of the next).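

In this assay, the position on a saturated chain carbon bound to an aromatic nitrogen proves sensitive to the group it carries: 2,3-dihydro-1H-indol-4-yl in place of 3-methylphenyl gives a number 1.50 log units lower from compound 2 to compound 3 (beyond the scatter), and in place of 4-methylphenyl it gives a number 1.40 log units lower from compound 1 to compound 3 (beyond the scatter). For the compounds shown here, the two methylphenyl groups showed no separation at this position, so these are the first steps here that lie beyond the scatter, and they come with one nitrogen, one hydrogen-bond donor and one hydrogen-bond acceptor entering together. No measurement bearing on the origin of these steps is available.

The compounds shown leave open which part of the entering group carries the step. A 3-aminophenyl group or 2,3-dihydro-1H-inden-4-yl, with carbon in place of the ring nitrogen, at this position would separate these contributions.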